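Replacing the acid at the anilide end of the thiazole series

The compounds below may be only part of what the source reports. "The series", "measured", "known", "first", "only" and "open" are said of these compounds alone.

Compound 3 `Cc1nc(-c2ccc(C(F)(F)F)cc2)sc1CNc1ccc(OCC(=O)O)cc1` stands highest of the three measured compounds in a functional assay on CHO cells for agonist activity at Free fatty acid receptor 1 (Homo sapiens), read by a luciferase reporter (a lower number here means a smaller maximal response, a higher number a larger maximal response), where compound 3 reaches 100%. Compound 1 `Cc1nc(-c2ccc(C(F)(F)F)cc2)sc1CNc1ccc(C(=O)O)cc1` gives 10% and compound 2 `Cc1nc(-c2ccc(C(F)(F)F)cc2)sc1CNc1ccc(CCCC(=O)O)cc1` gives 44%. The steps between them are all large: a number 90 percentage points higher from compound 1 to compound 3 (beyond the scatter), a number 56 percentage points higher from compound 2 to compound 3 (beyond the scatter) and a number 34 percentage points higher from compound 1 to compound 2 (beyond the scatter), each beyond the scatter. Compound 4 `Cc1nc(-c2ccc(C(F)(F)F)cc2)sc1CNc1ccc(CCC(N)=O)cc1` differs from compound 3 at the same aromatic carbon: 2-carbamoylethyl in place of carboxymethoxy on an aromatic carbon. Among the compounds with values here, no measured step covers this change, since every measured compound carries a carboxylic acid and compound 4 does not; the measured steps show only that changing the group at this position shifts the maximal response strongly in either direction. Because compound 3 gives 100% with the carboxymethoxy group, and the three acid-bearing variants span a number 90 percentage points higher from compound 1 to compound 3 (beyond the scatter), a downward step is expected for compound 4, of roughly a number 70 percentage points lower from compound 3 to compound 4 (beyond the scatter). Compound 4 is therefore estimated at 30% in this assay, within a range of 5% to 70%, with considerable uncertainty.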

Compound 4, largest response reached (reported as percent of maximum), in percent of the reference or control that the assay uses: 88%
For compound 4 the middle estimate is 58 percentage points below the measured one; the measured number lies above the stated range.
By their numbers in this assay, from the lowest: compound 1; then compound 2; then compound 4; then compound 3.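

In this assay the maximal response at this position does not depend on a carboxylic acid: the 2-carbamoylethyl group carries none, and the result is only a number 12 percentage points lower from compound 3 to compound 4 (beyond the scatter) and also a number 78 percentage points higher from compound 1 to compound 4 (beyond the scatter) in the same series. Carbamoyl in place of carboxymethyl on the saturated chain gives a number 44 percentage points higher from compound 2 to compound 4 (beyond the scatter) and so places this neutral amide well above two of the three acids, leaving only the carboxymethoxy compound ahead of it. Nothing measured here explains these steps.

What the compounds leave open is how much of the step from compound 2 belongs to the amide end group and how much to the chain, since that change alters both. A 2-carboxyethyl group, a 3-carbamoylpropyl group or a carbamoylmethoxy group at this aromatic carbon would separate the two.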